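This account rests on a few compounds, and the source may have more. Where it says the series, first, only, none or still open, it means among the compounds named here.

Compound 1 `CNC(=O)c1cccc(NC(=O)N2CCC(Oc3ccccc3)CC2)c1` is the starting point, and in an assay on isolated protein for inhibition of acyl-CoA desaturase 1 (Mus musculus) (on this read-out higher numbers stand for weaker inhibition and lower numbers for stronger inhibition), compound 1 gives 370 nM. Compound 2 `CNC(=O)c1cccc(NC(=O)N2CCC(Oc3ccccc3Br)CC2)c1` carries a bromo in place of hydrogen on an aromatic carbon, and an at least 92-fold lower number from compound 1 to compound 2 (1.96 log units; beyond the scatter). In this assay compound 2 gives < 4 nM, which is a limit rather than a number, as the limit of < 4 nM in this assay, at which 1 of the 2 values shown sits, shows. Compound 3 `CNC(=O)c1cccc(NC(=O)N2CCC(Oc3cc(F)ccc3Cl)CC2)c1` differs from compound 2 by 2-chloro-5-fluorophenyl in place of 2-bromophenyl on an oxygen on a saturated carbon. Within the data shown here, the only measured step bearing on this change is an at least 92-fold lower number from compound 1 to compound 2 (1.96 log units; beyond the scatter), where a halogen entered on an aromatic carbon; compound 3 keeps a halogen there, so the expected step in this assay is small, a number no lower from compound 2 to compound 3 (the limit leaves the size open). Compound 3 is therefore estimated at 4 nM, with a range of 1 nM to 15 nM.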

Compound 3, half-maximal inhibitory concentration: < 4 nM
Compound 3 gave a limit, no number; the forecaster's own chance of this, stated with the estimate: 40%; the middle value lies on the limit itself.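

Putting 2-chloro-5-fluorophenyl in place of phenyl on the oxygen also gives an at least 92-fold lower number from compound 1 to compound 3 (1.96 log units; beyond the scatter), so this large drop does not depend on bromine. The steps between compound 2 and compound 3 cannot be read, so their two groups cannot be ranked, and both measurements stop at a limit of the assay rather than a number: the limit of < 4 nM in this assay, at which 2 of the 3 values shown sit.

Still open, on these data alone, is whether a halogen is needed at all, since a methyl, a methoxy or an amine on this phenyl ring could behave differently. Also open, as far as these compounds go, is what the chloro and the fluoro each contribute in compound 3.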